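The source may report more compounds than this note shows. Statements on the series, on what has been measured and on what is new or still open speak of the compounds shown alone.

Measured so far in a functional assay on UACC-62 cells (Homo sapiens) for inhibition, read by sulforhodamine B assay, with a stated time of 48 h; on this read-out higher numbers stand for weaker inhibition of growth and lower numbers for stronger inhibition of growth:
compound 1 `Nc1cc(N)c2nc(-c3ccccc3)c(Sc3ccc(F)cc3)nc2c1` gives 16600 nM;
compound 2 `COc1cc(CNc2nc3cc(N)cc(N)c3nc2-c2ccccc2)cc(OC)c1OC` gives 8130 nM;
compound 3 `CCOC(=O)[C@H](CCC(=O)O)NC(=O)c1ccc(Oc2nc3cc(N)cc(N)c3nc2-c2ccccc2)cc1` gives 16200 nM.

Compound 1 has the highest number of the three. Compound 3 lies within the scatter of it, so the two cannot be told apart, while compound 2 stands apart with a lower number, beyond the scatter.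

Compound 4 `Nc1cc(N)c2nc(-c3ccccc3)c(NCc3ccc(F)cc3)nc2c1` differs from compound 1 in one place: (4-fluorobenzyl)amino in place of (4-fluorophenyl)sulfanyl on an aromatic carbon. The newcomer group brings a hydrogen-bond donor to a position where compound 1 had none, and compound 2, which also carries an amino-linked group on the shared core, shows the lower number. A modest move toward a lower number in this assay is therefore expected, near the edge of the scatter, estimated as a 1.8-fold lower number from compound 1 to compound 4 (0.27 log units; within the scatter). Compound 4 is expected to give about 9000 nM, likely between 3500 nM and 25000 nM.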

Compound 4, concentration for 50% growth inhibition: 15500 nM
Compound 4: the middle estimate sits 1.7-fold (0.24 log units) below what was measured, within the range that was stated.
By their numbers in this assay, from the lowest: compounds 2, 4, 3 and 1 (each within the scatter of the next, the first and the last beyond it).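

In this assay, putting (4-fluorobenzyl)amino in place of (4-fluorophenyl)sulfanyl on this aromatic carbon gives a 1.1-fold lower number from compound 1 to compound 4 (0.03 log units; within the scatter). The two groups therefore cannot be told apart here, even though the entering group carries a hydrogen-bond donor and the leaving group carries none. No measurement shown here accounts for this result. On these data alone, it remains open whether a plain amino group on this carbon, or a longer chain such as (4-fluorophenethyl)amino, would shift the number beyond the scatter. As far as these compounds go, the part played by the fluorine also remains open.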